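A few compounds are considered here, and "the series" means these few. Any claim that something is new, unique, unknown or untested is made for them only; others in the source may bear on it.

Of the compounds shown here, two have been measured in an assay (Mus musculus) for binding affinity to Folylpolyglutamate synthase, mitochondrial (Homo sapiens) (a lower number here means a stronger inhibitor, a higher number a weaker inhibitor), so far. Compound 1 `CN(Cc1cnc2nc(N)nc(N)c2n1)c1ccc(C(=O)NC(CS(=O)(=O)O)C(=O)O)cc1` gives 136000 nM in this assay. Compound 2 `Nc1nc(N)c2nc(CNc3ccc(C(=O)NC(CCS(=O)(=O)O)C(=O)O)cc3)cnc2n1` gives 59000 nM in this assay, the lower of the two numbers, and the gap to compound 1 lies beyond the scatter of repeated measurements.

Compound 3 `Nc1nc(N)c2nc(CNc3ccc(C(=O)NC(CS(=O)(=O)O)C(=O)O)cc3)cnc2n1` has not yet been measured. It differs from compound 2 in one place: sulfo in place of sulfomethyl on a saturated chain carbon, two bonds along the chain from an amide-type nitrogen and a carbonyl carbon. Going by the values given here, since this pair of measured compounds does not share a single point of difference, no measured step tells how this change alone acts; compound 1 carries the same sulfomethyl chain but is altered elsewhere as well, so its value shows only where a related compound with the shorter chain landed.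

On this footing the step from compound 2 to compound 3 is expected to raise the number by a modest amount, estimated as a 1.7-fold higher number from compound 2 to compound 3 (0.23 log units; within the scatter). Compound 3 is estimated to give 100000 nM in this assay, within a range from 40000 nM to 250000 nM.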

Compound 3, inhibition constant: 43000 nM
Estimate against measurement, compound 3: 2.3-fold (0.37 log units) above; measured number inside the range.
By their numbers in this assay, from the lowest: compounds 3 and 2 (each within the scatter of the next); then compound 1.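

In this assay, sulfo in place of sulfomethyl on a saturated chain carbon gives a 1.4-fold lower number from compound 2 to compound 3 (0.14 log units; within the scatter) and stays within the scatter, so the two chain lengths, 1-carboxy-3-sulfopropyl and 1-carboxy-2-sulfoethyl, cannot be told apart in this assay. The gap between compound 1 and compound 2 spanned two changes at once, whereas hydrogen in place of methyl on a nitrogen on an aromatic ring now stands alone as a 3.2-fold lower number from compound 1 to compound 3 (0.50 log units; beyond the scatter) and lies beyond the scatter, though modest in size. Going by these compounds alone, of the two changes, only the one on that nitrogen moves the number beyond the scatter, and nothing available explains why.

Open, as far as these compounds go, is how a carboxylic acid in place of the sulfo group would read at this chain position. Also open, from the compounds shown here alone, are a chain longer than 2-sulfoethyl and an ethyl group on that nitrogen.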